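The source may hold more compounds than are shown below. What is called first, only, known or untested is meant among the compounds shown, and "the series" means these compounds.

Series notes. Compound 1 `CC(C)C(NS(=O)(=O)c1ccc(F)cc1)C1=CC(=O)c2c(O)ccc(O)c2C1=O` has no result in a functional assay on HL-60 cells (Homo sapiens) for cytotoxicity, read by MTT assay (on this read-out higher numbers stand for weaker inhibition and lower numbers for stronger inhibition), where its entry reads "not determined" (no result reported). Within the data shown here, compound 2 `CC(C)C(NS(=O)(=O)c1ccccc1Br)C1=CC(=O)c2c(O)ccc(O)c2C1=O` gives 340 nM in this assay, while compound 3 `CC(=O)c1ccc(S(=O)(=O)NC(C2=CC(=O)c3c(O)ccc(O)c3C2=O)C(C)C)cc1` gives 110 nM, the lowest of the two numbers available; the one measured step, a 3.1-fold lower number from compound 2 to compound 3 (0.49 log units; beyond the scatter), concerns the group on the sulfonyl sulfur only. Compound 4 `CC(=O)c1ccc(S(=O)(=O)NC(C)C2=CC(=O)c3c(O)ccc(O)c3C2=O)cc1` differs from compound 3 by methyl in place of isopropyl on a saturated chain carbon bound to a double-bonded ring carbon and a sulfonamide nitrogen. Among the measured compounds shown here, no measured step touches this saturated chain carbon, so the series gives no direct guide to the size or direction of the change. Compound 4 is therefore expected to stay near compound 3, with a step of a 1.6-fold higher number from compound 3 to compound 4 (0.21 log units; within the scatter) estimated to lie inside the scatter. The estimate for compound 4 in this assay is 180 nM, ranging from 60 nM to 550 nM.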

Compound 4, half-maximal inhibitory concentration: 260 nM
Estimate against measurement, compound 4: 1.4-fold (0.16 log units) below, within the range that was stated.
By their numbers in this assay, from the lowest: compound 3; then compounds 4 and 2 (each within the scatter of the next).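

Methyl in place of isopropyl on this saturated chain carbon gives in this assay a 2.4-fold higher number from compound 3 to compound 4 (0.37 log units; beyond the scatter) and so shows that this position, untouched by the earlier step, registers a change, with isopropyl giving the lower number of the pair. The reading holds only with 4-acetylphenyl on the sulfonyl sulfur. No measured property accounts for the step.

From the compounds shown here alone, whether a longer chain or an amine on this carbon would lower the number further stays open. So does whether the same step appears with 2-bromophenyl on the sulfonyl sulfur.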